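Microsomal stability notes: difluorophenyl step from compound 3

This account rests on a few compounds, and the source may have more. Where it says the series, first, only, none or still open, it means among the compounds named here.

Compound 3 `C[C@H](Nc1ncnc(N)c1C#N)c1cc(=O)n2cc(F)ccc2c1-c1ccccc1` was tested in an ADME assay on microsomes from liver (Rattus norvegicus), read by LC-MS, using NADPH, with a stated time of 30 min, tested at 1 uM (on this read-out lower numbers stand for a less stable compound and higher numbers for a more stable compound), and compound 3 gives 74%. Compound 1 `C[C@H](Nc1nc(N)ncc1C#N)c1cc2ccc(F)cn2c(=O)c1-c1ccccc1` gives 74% in this assay, so compound 3 stands level with compound 1 at the digits shown, within the scatter. For compound 2 `C[C@H](Nc1nc(N)nc(N)c1C#N)c1cc(=O)n2cc(F)ccc2c1-c1ccccc1` this assay reports "not determined" (no result reported), so no number is available. Compound 4 `C[C@H](Nc1ncnc(N)c1C#N)c1cc(=O)n2cc(F)ccc2c1-c1cc(F)cc(F)c1` is not yet measured; it differs from compound 3 by 3,5-difluorophenyl in place of phenyl on an aromatic carbon. Within the data shown here, no measured pair isolates such a change, so the size of the step in this assay is not known from these data; a step no larger than the scatter, if anything slightly upward, is expected. For compound 4 the estimated result is 78%, with a range from 62% to 92%, meaning an expected step of a number 4 percentage points higher from compound 3 to compound 4 (within the scatter).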

Compound 4, percent of the compound remaining: 60%
Beside the measured number, compound 4's estimate is 18 percentage points above it; the measured number lies below the stated range.
By their numbers in this assay, from the lowest: compound 4; then compounds 1 and 3 (each within the scatter of the next).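

Among these compounds, with 3,5-difluorophenyl in place of phenyl on this aromatic carbon, this assay shows a number 14 percentage points lower from compound 3 to compound 4 (beyond the scatter) as the first readable step at this position. The read-out therefore responds to a change on this phenyl, and here the added fluorines go with less compound remaining. No measurement here accounts for the step.

From the compounds shown here alone, whether a single fluorine on the phenyl, or a methoxy group in place of the fluorines, gives a similar step stays open. Also open, going by these compounds, is whether the step carries over to the core of compound 1.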